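Replacing an Isobutyl Amide with a Dimethoxyphenyl Amide

This account rests on a few compounds, and the source may have more. Where it says the series, first, only, none or still open, it means among the compounds named here.

Three compounds have been measured in an in vitro assay on BTI-TN-5B1-4 cells for inhibition of Amine oxidase [flavin-containing] A (Homo sapiens), read by fluorescence; a higher number here means a weaker inhibitor, a lower number a stronger inhibitor:

compound 1, `CCc1ccc(NC(=O)c2cc3ccccc3oc2=O)cc1`, gives 15700 nM
compound 2, `CC(C)NC(=O)c1cc2ccc(OCc3ccccc3)cc2oc1=O`, gives 63500 nM
compound 3, `CC(C)CNC(=O)c1cc2ccc(OCc3ccccc3)cc2oc1=O`, gives 58600 nM

Among these three numbers compound 3 sits second highest. Its nearest neighbour is compound 2, whose number is close enough to lie within the usual scatter, while compound 1 gives a clearly lower number, a gap beyond the scatter. Compound 1 differs from compound 3 in two places at once, so the two values can only be set side by side, not read as a single step.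

Compound 4, `COc1cc(NC(=O)c2cc3ccc(OCc4ccccc4)cc3oc2=O)cc(OC)c1`, has not yet been measured. It differs from compound 3 in one place: 3,5-dimethoxyphenyl in place of isobutyl on an amide-type nitrogen. Going by the values given here, the only single step measured so far, a 1.1-fold lower number from compound 2 to compound 3 (0.03 log units; within the scatter), swaps one small alkyl group for another on the same nitrogen and changes the number hardly at all. Among the compounds with values here, no measured step exchanges an alkyl group for an aromatic one on this nitrogen, so the data give no direct guide to the size of the coming change. Within the data shown here, the only hint is that compound 1, the sole aryl amide here, gives the lowest number of the three.

On that basis compound 4 is expected to give a somewhat lower number than compound 3, an estimated step of a 2.7-fold lower number from compound 3 to compound 4 (0.43 log units; beyond the scatter), though with wide uncertainty. The estimate for compound 4 in this assay is 22000 nM, with a likely range from 6000 nM to 70000 nM.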

Compound 4, half-maximal inhibitory concentration: 52900 nM
The estimate for compound 4 lay 2.4-fold (0.38 log units) below the measured number, within the range that was stated.
By their numbers in this assay, from the lowest: compound 1; then compounds 4, 3 and 2 (each within the scatter of the next).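

In this assay, 3,5-dimethoxyphenyl in place of isobutyl on the amide-type nitrogen gives a 1.1-fold lower number from compound 3 to compound 4 (0.04 log units; within the scatter), and the same group in place of isopropyl gives a 1.2-fold lower number from compound 2 to compound 4 (0.08 log units; within the scatter), so an aromatic ring of 10 heavy atoms with 2 hydrogen-bond acceptors does no differently here from a small alkyl group. Going by these compounds alone, the earlier step, a 1.1-fold lower number from compound 2 to compound 3 (0.03 log units; within the scatter), compared only two small alkyl groups, whereas the three compounds now show that this nitrogen tolerates a much larger change of group with no shift beyond the scatter, at least among isopropyl, isobutyl and 3,5-dimethoxyphenyl on this shared core. Nothing available explains why the number stays so flat across these groups.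

The compounds shown leave open whether a plain phenyl, a longer chain, or a chain ending in an amine or a carboxylic acid would behave the same way on this nitrogen. They also leave open whether the flat result holds on a core without the benzyloxy group, since compound 1 differs from the others in more than one place and cannot settle that.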